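Swapping a pyrazole for a dimethyl oxolane ring

A few compounds are considered here, and "the series" means these few. Any claim that something is new, unique, unknown or untested is made for them only; others in the source may bear on it.

Measured compounds:
compound 1 `COc1cc(-c2cnn3cc(OC)c(C4CCCC4)nc23)ccn1` gives 2900 nM in an assay on isolated protein for inhibition of activin receptor type-2A (Homo sapiens), read by 33P incorporation, with a stated time of 20 min, in the presence of a further agent that is not named here; a higher number here means a weaker inhibitor, a lower number a stronger inhibitor
compound 2 `COc1cc(-c2cnn3cc(OC)c(C(C)(C)O)nc23)ccn1` gives 2700 nM
compound 3 `COc1cc(-c2cnn3cc(OC)c(-c4cnn(C)c4)nc23)ccn1` gives 530 nM

Among these three, compound 3 holds the lowest number in this assay; the steps that lead to it are a 5.1-fold lower number from compound 2 to compound 3 (0.71 log units; beyond the scatter) and a 5.5-fold lower number from compound 1 to compound 3 (0.74 log units; beyond the scatter), both beyond the scatter. Compounds 1 and 2 themselves sit within the scatter of one another, the step being a 1.1-fold lower number from compound 1 to compound 2 (0.03 log units; within the scatter).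

Compound 4 `COc1cc(-c2cnn3cc(OC)c([C@H]4COC(C)(C)C4)nc23)ccn1` has not yet been measured. It differs from compound 3 in one place: a group of 7 heavy atoms (6 carbon, 1 oxygen; one five-membered non-aromatic ring with 1 hetero atom) in place of a group of 6 heavy atoms (4 carbon, 2 nitrogen; one five-membered aromatic ring with 2 hetero atoms), on an aromatic carbon. In compound 3 the five-membered aromatic ring with 2 hetero atoms is the feature that sets it apart from compounds 1 and 2, which carry a cyclopentyl and a 1-hydroxy-1-methylethyl group and give higher numbers. The group entering in compound 4 is, like cyclopentyl, a five-membered non-aromatic ring. Within the data shown here, the steps that bear on the change are therefore a 5.5-fold lower number from compound 1 to compound 3 (0.74 log units; beyond the scatter) and a 5.1-fold lower number from compound 2 to compound 3 (0.71 log units; beyond the scatter), and the reverse of such a step is expected here: a modest rise in the number for compound 4 relative to compound 3, estimated as a 3.8-fold higher number from compound 3 to compound 4 (0.58 log units; beyond the scatter). Compound 4 is thus expected to give about 2000 nM, with a range from 800 nM to 5000 nM.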

Compound 4, half-maximal inhibitory concentration: 4100 nM
For compound 4 the middle estimate is 2.1-fold (0.31 log units) below the measured one; low and high end bracket the measured number.
By their numbers in this assay, from the lowest: compound 3; then compounds 2, 1 and 4 (each within the scatter of the next).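

Set against the 1-methyl-1H-pyrazol-4-yl group, the group entering here gives a 7.7-fold higher number from compound 3 to compound 4 (0.89 log units; beyond the scatter) in this assay, which places a third non-aromatic group on this aromatic carbon with the same outcome as the first two. Its steps to the earlier non-aromatic compounds, a 1.4-fold higher number from compound 1 to compound 4 (0.15 log units; within the scatter) and a 1.5-fold higher number from compound 2 to compound 4 (0.18 log units; within the scatter), stay within the scatter, so the hetero atom in the five-membered non-aromatic ring brings no measurable gain over cyclopentyl, and the extra ring brings none over 1-hydroxy-1-methylethyl; among these four compounds, compound 3, the only one with a five-membered aromatic ring at this position, stands apart, and none goes against that pattern. No measurement shown here explains this separation.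

The compounds leave open whether an aromatic ring as such is what matters at this position, since a phenyl ring, a pyridine ring or a pyrazole without its methyl group would be needed to separate that from the particular 1-methyl-1H-pyrazol-4-yl group. They also leave open how a ring amine such as piperidine would read here, and whether the opposite stereocentre of the group in compound 4 would read any differently.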